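A few compounds are considered here, and "the series" means these few. Any claim that something is new, unique, unknown or untested is made for them only; others in the source may bear on it.

Series notes. Compound 2 `C[C@H](NCC1CCN(CCCc2c[nH]c3ccc(-n4cnnc4)cc23)CC1)c1ccccc1` carries a ((1-phenylethyl)amino)methyl group on a saturated ring carbon of the shared core; in an assay on CHO cells for displacement of a labelled ligand from 5-hydroxytryptamine receptor 1B (Homo sapiens) (a higher number here means a weaker inhibitor, a lower number a stronger inhibitor), compound 2 gives 58 nM. Among the measured compounds shown here, compound 1 `c1cc(CNC2CCN(CCCc3c[nH]c4ccc(-n5cnnc5)cc34)CC2)co1` is the only other measured member, and in this assay compound 1 gives 78 nM. Compound 2 thus holds the lower of the two numbers, but the step of a 1.3-fold lower number from compound 1 to compound 2 (0.13 log units; within the scatter) lies within the scatter, so the two values cannot be ordered with any confidence.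

Compound 3 `CN(Cc1ccco1)C1CCN(CCCc2c[nH]c3ccc(-n4cnnc4)cc23)CC1` has not been measured. Relative to compound 2 the change is ((furan-2-yl)methyl)(methyl)amino in place of ((1-phenylethyl)amino)methyl on a saturated ring carbon. For the measured compounds named here, the one measured step that bears on this position, a 1.3-fold lower number from compound 1 to compound 2 (0.13 log units; within the scatter), exchanged a furan-bearing amine side chain for the phenylethyl one and moved the number only within the scatter. Going by the values given here, compound 3 returns to a furan-bearing side chain, now with a methyl on the nitrogen; no measured pair addresses that methyl or the shift of the furan attachment. The step expected here is a 1.4-fold higher number from compound 2 to compound 3 (0.14 log units; within the scatter), nothing beyond the scatter. For compound 3 the estimate in this assay is 80 nM, in a range from 35 nM to 180 nM.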

Compound 3, half-maximal inhibitory concentration: 89 nM
Compound 3: middle estimate off by 1.1-fold (0.05 log units), on the low side, within the range that was stated.
By their numbers in this assay, from the lowest: compounds 2, 1 and 3 (each within the scatter of the next).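

Working notes on the saturated ring carbon. In this assay, the exchange of ((1-phenylethyl)amino)methyl for ((furan-2-yl)methyl)(methyl)amino gives a 1.5-fold higher number from compound 2 to compound 3 (0.19 log units; within the scatter), although the entering group has 0 hydrogen-bond donors against 1 in the group that leaves, has a five-membered aromatic ring with 1 hetero atom in place of a six-membered aromatic ring of carbon only, and has no defined stereocentre. The exchange of ((furan-3-yl)methyl)amino for the same group gives a 1.1-fold higher number from compound 1 to compound 3 (0.06 log units; within the scatter), so all three side chains now lie within the scatter of one another, and this position has so far tolerated these differences without a resolved change in the number. No evidence is available that accounts for this flatness.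

The step from compound 1 to compound 3 changes the methyl on the nitrogen and the furan attachment together, so the contribution of each remains unresolved. Going by these compounds, it also remains open whether a carboxylic acid, an amide or a longer chain at this saturated ring carbon would move the number in this assay beyond the scatter.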